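The compounds below may be only part of what the source reports. "The series", "measured", "known", "first", "only" and "open" are said of these compounds alone.

Compound 1 `C/C(=C\CC/C(C)=C/CC[C@@H]1[C@@]2(C)CCC(=O)C(C)(C)[C@H]2CC[C@@]1(C)O)CC/C=C(\C)C(=O)OCc1cn(-c2ccccc2C)nn1` and compound 2 `COc1cccc(-n2cc(COC(=O)/C(C)=C/CC/C(C)=C/CC/C(C)=C/CC[C@@H]3[C@@]4(C)CCC(=O)C(C)(C)[C@H]4CC[C@@]3(C)O)nn2)c1` share one core and differ only in the group on an aromatic nitrogen. In a functional assay on DU-145 cells (Homo sapiens) for antiproliferative activity, read by MTT assay, with a stated time of 48 h (a higher number here means a weaker inhibitor, a lower number a stronger inhibitor), compound 1 gives > 150000 nM, which is a limit of the assay and not a number. Compound 2 gives > 150000 nM, likewise a limit and not a number. Compound 2 therefore has no measured potency of its own, and all that the series shows so far is the limit of > 150000 nM in this assay, at which 2 of the 2 values shown sit. For the measured compounds named here, the only measured step, a step that the two limits leave unreadable from compound 1 to compound 2, has no readable size.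

Compound 3 `C/C(=C\CC/C(C)=C/CC[C@@H]1[C@@]2(C)CCC(=O)C(C)(C)[C@H]2CC[C@@]1(C)O)CC/C=C(\C)C(=O)OCc1cn(-c2cccc(O)c2)nn1` takes compound 2 from 3-methoxyphenyl to 3-hydroxyphenyl, with hydrogen in place of methyl on an oxygen on an aromatic ring. Going by the values given here, no measured step covers this change. Because the limit of > 150000 nM in this assay, at which 2 of the 2 values shown sit, is the whole of the evidence, no step beyond the scatter is expected in this assay, in either direction, and the assay will probably report only a limit again. The expected size is a number no higher from compound 2 to compound 3 (the limit leaves the size open). For compound 3 the estimate is 150000 nM, with an expected range from 70000 nM to 300000 nM.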

Compound 3, half-maximal inhibitory concentration: 28400 nM
Beside the measured number, compound 3's estimate is 5.3-fold (0.72 log units) above it; measured number below the stated range.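

In this assay, for the compounds shown here, hydrogen in place of methyl on an oxygen on an aromatic ring, which turns 3-methoxyphenyl into 3-hydroxyphenyl, gives an at least 5.2-fold lower number from compound 2 to compound 3 (0.72 log units; beyond the scatter), the first step with a readable size. Measured against the 2-methylphenyl group on the aromatic nitrogen, the 3-hydroxyphenyl group likewise gives an at least 5.2-fold lower number from compound 1 to compound 3 (0.72 log units; beyond the scatter). The group on the aromatic nitrogen can therefore bring a number into the measurable range, which the earlier compounds could not show, and among the compounds shown only the one carrying hydroxy has done so, while the other two remain at a limit of the assay: the limit of > 150000 nM in this assay, at which 2 of the 3 values shown sit.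

On these data alone, both readable steps start from a limit, so their full size stays open, and the step from compound 1 to compound 2 cannot be read. As far as these compounds go, it also stays open whether an amine or a carboxylic acid in place of the hydroxy would give a number in the same range, and whether a longer chain on that oxygen would return the value to the limit.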